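Phenyl for Cyclohexyl on the Hydroxypropyl Series

The source may hold more compounds than are shown below. What is called first, only, known or untested is meant among the compounds shown, and "the series" means these compounds.

Compound 1, `CCN(CC)c1ccc(/C=C2\C(=O)N(C3CCCCC3)C(=S)N2C)cc1`, in an assay on isolated protein for inhibition of NADPH oxidase 2 (Homo sapiens), read by chemiluminescence, in the presence of a further agent that is not named here (a higher number here means a weaker inhibitor, a lower number a stronger inhibitor), gives 5660 nM.
Compound 2, `CCN(CC)c1ccc(/C=C2\C(=O)N(c3ccccc3)C(=S)N2C)cc1`, in this assay gives 1960 nM.
Compound 3, `CN1C(=S)N(C2CCCCC2)C(=O)/C1=C\c1ccc(N(C)CCCO)cc1`, in this assay gives 2400 nM.

Compound 3 stands second highest of the three numbers shown. Its value is within the scatter of that of compound 2, and it is separated from compound 1 by a step beyond the scatter, a 2.4-fold lower number from compound 1 to compound 3 (0.37 log units; beyond the scatter). Compound 4, `CN1C(=S)N(c2ccccc2)C(=O)/C1=C\c1ccc(N(C)CCCO)cc1`, has not yet been measured. It differs from compound 3 in one place: phenyl in place of cyclohexyl on an amide-type nitrogen in a ring. The same exchange has been made once among the measured compounds, on the core that carries the diethylamino group, where it gave a 2.9-fold lower number from compound 1 to compound 2 (0.46 log units; beyond the scatter). Going by the values given here, that is the only measured step that bears on the change; how the exchange behaves on the core bearing the (3-hydroxypropyl)(methyl)amino group is not known from these data. If the step carries over, compound 4 is expected to give a lower number in this assay than compound 3, a modest step beyond the scatter. The step so expected for compound 4 is a 2.9-fold lower number from compound 3 to compound 4 (0.46 log units; beyond the scatter). Compound 4 is accordingly estimated at 830 nM, with a range from 400 nM to 1700 nM.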

Compound 4, half-maximal inhibitory concentration: 2720 nM
For compound 4 the middle estimate is 3.3-fold (0.52 log units) below the measured one, outside the stated range (above it).
By their numbers in this assay, from the lowest: compounds 2, 3 and 4 (each within the scatter of the next); then compound 1.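

On the core bearing the (3-hydroxypropyl)(methyl)amino group, phenyl in place of cyclohexyl on the amide-type nitrogen in a ring gives a 1.1-fold higher number from compound 3 to compound 4 (0.05 log units; within the scatter) in this assay, so the step seen on the diethylamino core does not recur here. What this exchange does at this position therefore depends on the group on the aromatic carbon of the shared core: the same change on two cores in this assay, a 2.9-fold lower number (0.46 log units; beyond the scatter) from compound 1 to compound 2 and a 1.1-fold higher number (0.05 log units; within the scatter) from compound 3 to compound 4, 3.3-fold (0.51 log units) apart, beyond the scatter of two such steps Read the other way, (3-hydroxypropyl)(methyl)amino in place of diethylamino gives a 1.4-fold higher number from compound 2 to compound 4 (0.14 log units; within the scatter) when phenyl is present, so the two exchanges do not add up, and either one alone accounts for about as much as both together: the same change on two cores in this assay, a 2.4-fold lower number (0.37 log units; beyond the scatter) from compound 1 to compound 3 and a 1.4-fold higher number (0.14 log units; within the scatter) from compound 2 to compound 4, 3.3-fold (0.51 log units) apart, beyond the scatter of two such steps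

The compounds shown offer only two groups at each place, so it remains open whether a longer chain on the amine nitrogen, a carboxylic acid in place of the hydroxyl, or a benzyl on the ring nitrogen would follow compound 2 or compound 4. They also do not tell why the exchange depends on the core in this way.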